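Replacing a diethylamide with a methylamide on a shared core

A few compounds are considered here, and "the series" means these few. Any claim that something is new, unique, unknown or untested is made for them only; others in the source may bear on it.

Compound 1, `CCOC(=O)N1CCC[C@H](S(=O)(=O)c2ccc(S(=O)(=O)N(CC)CC)cc2)C1`, in a functional assay on MIA PaCa-2 cells (Homo sapiens) for inhibition, read by MTT assay, with a stated time of 3 days (on this read-out lower numbers stand for stronger inhibition and higher numbers for weaker inhibition), gives only a limit: > 10000 nM.
Compound 2, `CCN(CC)C(=O)[C@@H]1CCCN(S(=O)(=O)c2ccc(S(=O)(=O)N(CC)CC)cc2)C1`, in this assay likewise gives only a limit: > 10000 nM.

Among the compounds with values here, compound 2 thus stands at no measured number at all; its value is a limit of the assay, and the one further value shown is also a limit. Both sit at the limit of > 10000 nM in this assay, at which 2 of the 2 values shown sit, so nothing separates the two measured compounds. Compound 3, `CCN(CC)S(=O)(=O)c1ccc(S(=O)(=O)N2CCC[C@@H](C(=O)NC)C2)cc1`, differs from compound 2 in a single place: methylamino in place of diethylamino on a carbonyl carbon. Within the data shown here, no step between measured compounds is available, and the change at the carbonyl carbon is small in size. In this assay the expected step from compound 2 to compound 3 is therefore none beyond the usual scatter, with a fair chance of another limit. Compound 3 is estimated at 15000 nM, the expected range spanning 3000 nM to 60000 nM, which is to say a step that the limit leaves unreadable from compound 2 to compound 3.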

Compound 3, half-maximal inhibitory concentration: > 10000 nM
Compound 3: no number, only a limit; the forecaster's own chance of this, stated with the estimate: 80%; the middle value is on the limit's open side.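

In this assay compound 3 gives only a limit, > 10000 nM. No step can be read from compound 2 to compound 3, since both values are limits: the limit of > 10000 nM in this assay, at which 3 of the 3 values shown sit.

Going by these compounds, whether methylamino in place of diethylamino on a carbonyl carbon changes inhibition at all remains open.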